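The source may hold more compounds than are shown below. What is called first, only, known or untested is meant among the compounds shown, and "the series" means these compounds.

In a functional assay on the whole organism for antagonist activity, with Mus musculus as the target (a lower number here means that less compound is needed, a higher number that more compound is needed for the effect), compound 2 `Cn1ccn(CC#CCn2ccnc2)c1=O` gives only the limit > 100 mg/kg, a limit of the assay rather than a number. Compound 1 `Cn1ccn(CC#CCN2CCCC2)c1=O` likewise gives only the limit > 10 mg/kg. Compound 3 `Cc1cncn1CC#CCn1ccn(C)c1=O` gives a readable value of 8 mg/kg. The step that the two limits leave unreadable from compound 1 to compound 2 cannot be sized, with both of its ends at limits. The step of an at least 12-fold lower number from compound 2 to compound 3 (1.09 log units; beyond the scatter) is large and comes from a methyl in place of hydrogen on an aromatic carbon. Compound 4 `CN(C)CC#CCn1ccn(C)c1=O` has not been measured. It differs from compound 2 by dimethylamino in place of 1H-imidazol-1-yl on a saturated chain carbon bound to a triple-bonded carbon. The nearest measured guide is compound 1, which carries a saturated amine in the same place and still sits at a limit, as the limit of > 10 mg/kg in this assay, at which 1 of the 3 values shown sits, shows; compound 2 sits at the limit given by the limit of > 100 mg/kg in this assay, at which 1 of the 3 values shown sits. No measured step sizes this change, so the expected step of an at least 3.3-fold lower number from compound 2 to compound 4 (0.52 log units; beyond the scatter) is uncertain and rests mainly on the limit for compound 1. Compound 4 is therefore estimated at 30 mg/kg, between 8 mg/kg and 100 mg/kg, and a limit may again be all that is read.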

Compound 4, dose for half-maximal effect: > 100 mg/kg
Compound 4: a limit, no number (the forecaster's own chance of this, stated with the estimate: 50%); middle value at least 3.3-fold (0.52 log units) from the limit.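

Compound 1, compound 2 and compound 4 each give only a limit, and the steps from compound 2 to compound 4 and from compound 1 to compound 4 cannot be read. The compounds shown leave open whether dimethylamino, pyrrolidin-1-yl and 1H-imidazol-1-yl differ at all in this assay.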